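From methylcarbamoyl to hydroxymethyl: compound 3 to compound 4

This account rests on a few compounds, and the source may have more. Where it says the series, first, only, none or still open, it means among the compounds named here.

Measured so far in a functional assay on cells (Platelet, Homo sapiens) for inhibition; a lower number here means a stronger inhibitor, a higher number a weaker inhibitor:
- Compound 1 `CCCCn1nc(-c2ccc(C(=O)OCC)cc2)c2ccccc21`: > 10000 nM, a limit
- Compound 2 `O=C(O)c1ccc(-c2nn(Cc3ccccc3)c3ccccc23)cc1`: > 10000 nM, a limit
- Compound 3 `CNC(=O)c1ccc(-c2nn(Cc3ccccc3)c3ccccc23)cc1`: > 10000 nM, a limit

None of the three results is a number. Compound 3 stands at a limit of the assay, > 10000 nM. Compound 4 `OCc1ccc(-c2nn(Cc3ccccc3)c3ccccc23)cc1` carries hydroxymethyl in place of methylcarbamoyl on an aromatic carbon of a six-membered aromatic ring of carbon only, para to a large group: hydroxymethyl in place of methylcarbamoyl on an aromatic carbon.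

Among the measured compounds shown here, the one measured step at this place is a step that the two limits leave unreadable from compound 2 to compound 3. It offers no size to carry over, and the three compounds share one position: the limit of > 10000 nM in this assay, at which 3 of the 3 values shown sit. Any change in this assay therefore has to be expected without a measured guide. The expected step that the limit leaves unreadable from compound 3 to compound 4 is a loose figure, with neither its size nor its direction supported by these data. Compound 4 may well also report only a limit. Compound 4 is estimated at 15000 nM, with an expected range from 3000 nM to 50000 nM.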

Compound 4, half-maximal inhibitory concentration: > 10000 nM
Compound 4: no number, only a limit; the forecaster's own chance of this, stated with the estimate: 65%; the middle value is on the limit's open side.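

No step from compound 2 or compound 3 to compound 4 can be read, since each result is a limit and not a number: the limit of > 10000 nM in this assay, at which 4 of the 4 values shown sit.

The compounds shown leave open whether carboxy, methylcarbamoyl or hydroxymethyl on the shared core makes any difference to inhibition, and how strong any of these compounds actually is.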